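A few compounds are considered here, and "the series" means these few. Any claim that something is new, unique, unknown or untested is made for them only; others in the source may bear on it.

Measured compounds in a functional assay on HL-60 cells (Homo sapiens) for cytotoxicity, read by WST assay, with a stated time of 48 h; on this read-out lower numbers stand for stronger inhibition and higher numbers for weaker inhibition:
compound 1, `CC(C)CC(=O)[C@@H]1O[C@@]12C(=O)C=C(Cc1ccccc1)NC2=O`, 37300 nM
compound 2, `CC1=CC(=O)[C@]2(O[C@@H]2C(=O)CC(C)C)C(=O)N1`, 1700 nM
compound 3, `CC1=CC(=O)C2(OC2C(=O)CC(C)C)C(=O)N1`, 1800 nM

Compound 3 stands second highest of the three numbers. Its nearest neighbour is compound 2, and the step of a 1.1-fold higher number from compound 2 to compound 3 (0.02 log units; within the scatter) lies within the scatter; the two compounds share all atoms and bonds and differ only in that compound 2 carries drawn configurations at both stereocentres while compound 3 carries none (the fact that one of compounds 2 and 3 is drawn with a defined configuration and the other without, at the place where they differ). Compound 1 stands far above both.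

Compound 4, `CC1=CC(=O)[C@@]2(O[C@H]2C(=O)CC(C)C)C(=O)N1`, is not yet measured. It differs from compound 3 as follows: the two compounds have the same atoms and bonds; at least one stereo element is drawn with a configuration in one of them and without one in the other: 2 of 2 stereo elements differ; a stereocentre at a saturated ring carbon is drawn without a configuration in compound 3 and R in compound 4; a stereocentre at a saturated ring carbon is drawn without a configuration in compound 3 and R in compound 4

Within the data shown here, the only measured step that bears on this change is the one from compound 2 to compound 3, which is within the scatter; there the undrawn form matched the form drawn S at both centres. Among the measured compounds shown here, compound 4 is the form drawn R at both centres, for which no counterpart exists among the measured compounds. The expectation is therefore a step of a 1.4-fold higher number from compound 3 to compound 4 (0.14 log units; within the scatter) of no clear direction beyond the scatter, with wide uncertainty because the step of a 1.1-fold higher number from compound 2 to compound 3 (0.02 log units; within the scatter) gives no information about the other drawn configuration. Compound 4 is estimated at 2500 nM, within 800 nM to 15000 nM, in this assay.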

Compound 4, half-maximal inhibitory concentration: 1600 nM
Compound 4: the middle estimate sits 1.6-fold (0.19 log units) above what was measured; low and high end bracket the measured number.
By their numbers in this assay, from the lowest: compounds 4, 2 and 3 (each within the scatter of the next); then compound 1.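

In this assay, inverting both stereocentres gives a 1.1-fold lower number from compound 2 to compound 4 (0.03 log units; within the scatter), so this pair shows no separation of the two drawn configurations beyond the scatter: the fact that compounds 2 and 4 differ only in the configuration as drawn. The form without drawn configurations also stays within the scatter of the form drawn R at both centres, with a 1.1-fold lower number from compound 3 to compound 4 (0.05 log units; within the scatter): the fact that one of compounds 3 and 4 is drawn with a defined configuration and the other without, at the place where they differ. Among these compounds, in contrast, hydrogen in place of phenyl on a saturated chain carbon bound to a double-bonded ring carbon gives the only large new step, a 23-fold lower number from compound 1 to compound 4 (1.37 log units; beyond the scatter), which makes that place, rather than the drawn configuration, the one that separates these compounds in this assay.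

As far as these compounds go, what a longer chain, an amine or a carboxylic acid would give at that place remains open. From the compounds shown here alone, whether the match between the mirror images holds for compound 1, with its phenyl, also remains open.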